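Replacing furan-3-yl with pyridin-2-yl in compound 3

A few compounds are considered here, and "the series" means these few. Any claim that something is new, unique, unknown or untested is made for them only; others in the source may bear on it.

Measured in an ADME assay on Vero cells (Chlorocebus sabaeus) for cytotoxicity, read by MTT assay, with a stated time of 96 h; on this read-out higher numbers stand for lower toxicity in this test and lower numbers for higher toxicity in this test:

- compound 1 `CC(=O)c1ccc2c(c1)nc(-c1ccc(Cl)cc1)n2C1CCCCC1` gives > 100000 nM (a limit of the assay)
- compound 2 `COc1ccc(-c2nc3cc(C(C)=O)ccc3n2C2CCCCC2)cc1` gives 30000 nM
- compound 3 `CC(=O)c1ccc2c(c1)nc(-c1ccoc1)n2C1CCCCC1` gives 80000 nM

Among the measured compounds shown here, of the two values that are actual numbers, compound 3 holds the higher, and the only comparison is with compound 2: a 2.7-fold higher number from compound 2 to compound 3 (0.43 log units; beyond the scatter). The value of compound 1 is a limit.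

Compound 4 `CC(=O)c1ccc2c(c1)nc(-c1ccccn1)n2C1CCCCC1` carries pyridin-2-yl in place of furan-3-yl on an aromatic carbon of the shared core (pyridin-2-yl in place of furan-3-yl on an aromatic carbon). Three measured steps changed the group at this same place. They are an at least 3.3-fold lower number from compound 1 to compound 2 (0.52 log units; beyond the scatter), then an at least 1.2-fold lower number from compound 1 to compound 3 (0.09 log units; that floor lies within the scatter), and the modest 2.7-fold higher number from compound 2 to compound 3 (0.43 log units; beyond the scatter). None of them involves pyridin-2-yl, so they give no firm direction, only a sense of size. An estimated 1.2-fold lower number from compound 3 to compound 4 (0.09 log units; within the scatter) is therefore expected, which means no step beyond the scatter. In this assay compound 4 is estimated at 65000 nM, with an expected range from 25000 nM to 120000 nM.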

Compound 4, half-maximal cytotoxic concentration: > 90000 nM
Compound 4: only a limit was reported; the forecaster's own chance of this, stated with the estimate: 20%; middle value at least 1.3-fold (0.14 log units) from the limit.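

In this assay, pyridin-2-yl at this place, on the aromatic carbon between two ring nitrogen atoms, gives an at least 3.0-fold higher number from compound 2 to compound 4 (0.47 log units; beyond the scatter), so a six-membered aromatic ring here does not by itself bring the lower number seen for compound 2. Against furan-3-yl the change gives an at least 1.1-fold higher number from compound 3 to compound 4 (0.05 log units; that floor lies within the scatter), and no order can be stated between these two compounds. The step between compound 1 and compound 4 cannot be read, because both of its ends are limits: the limit of > 90000 nM in this assay, at which 1 of the 4 values shown sits.

The compounds shown leave open where the actual numbers of compound 1 and compound 4 lie. They also leave open how this read-out responds at this place to pyridin-3-yl, to morpholine, or to an aminomethyl group or a carboxylic acid on the pyridin-2-yl ring.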